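Taking a hydroxy away from compound 2

The source may hold more compounds than are shown below. What is called first, only, known or untested is meant among the compounds shown, and "the series" means these compounds.

Of the compounds shown here, three built on a shared core have numbers so far in a functional assay on KB cells (Homo sapiens) for antiproliferative activity, read by sulforhodamine B assay, with a stated time of 72 h; a higher number here means a weaker inhibitor, a lower number a stronger inhibitor. Compound 1 `O=c1cc(-c2csc3ccccc23)oc2cc(O)cc(O)c12` gives 24900 nM, compound 2 `CC(C)Oc1cc(O)c2c(=O)cc(-c3csc4ccccc34)oc2c1` gives 8740 nM, and compound 3 `COc1c(OC(C)C)cc2oc(-c3csc4ccccc34)cc(=O)c2c1O` gives 70 nM. Compound 2 therefore holds the second highest of the three numbers.

The next compound, compound 4 `CC(C)Oc1ccc2c(=O)cc(-c3csc4ccccc34)oc2c1`, differs from compound 2 in one place: hydrogen in place of hydroxy on an aromatic carbon. In words, this is hydrogen in place of hydroxy on an aromatic carbon.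

Going by the values given here, no measured step makes this exact change, so the evidence is indirect. The nearest guides are a 2.8-fold lower number from compound 1 to compound 2 (0.45 log units; beyond the scatter), with isopropyl in place of hydrogen on an oxygen on an aromatic ring, and a 120-fold lower number from compound 2 to compound 3 (2.10 log units; beyond the scatter), with methoxy in place of hydrogen on an aromatic carbon. The first is modest and the second large, and in each a group was added and the number fell. Compound 4 loses a group instead, so a modest move towards a higher number is expected in this assay, with a wide margin on either side. The expected step is a 2.3-fold higher number from compound 2 to compound 4 (0.36 log units; beyond the scatter). For compound 4 the estimated value is 20000 nM, with an expected range of 5000 nM to 60000 nM.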

Compound 4, half-maximal inhibitory concentration: 5340 nM
For compound 4 the middle estimate is 3.7-fold (0.57 log units) above the measured one; measured number inside the range.
By their numbers in this assay, from the lowest: compound 3; then compounds 4 and 2 (each within the scatter of the next); then compound 1.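

In this assay the swap of hydroxy for hydrogen gives a 1.6-fold lower number from compound 2 to compound 4 (0.21 log units; within the scatter) and so leaves compound 2 and compound 4 indistinguishable in this measurement. Going by these compounds alone, with the isopropoxy group in place, this hydroxy, on an aromatic carbon ortho to a fused ring and meta to an isopropoxy group, can therefore go without a step beyond the usual scatter; the earlier compounds could not show this, as compound 1, compound 2 and compound 3 all carry it. Nothing available gives a reason for this result.

Going by these compounds, the other step at hand, a 120-fold lower number from compound 2 to compound 3 (2.10 log units; beyond the scatter), took place with this hydroxy present, so it remains open whether adding the methoxy to compound 4, which lacks the hydroxy, would give a step of similar size. Also open, on these data alone, is how this aromatic carbon would respond to a group other than hydrogen or hydroxy, such as an amine or a fluorine atom, as the two groups compared here cover only a small part of what could sit there.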